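What a methoxycarbonyl might change in cell toxicity

The source may report more compounds than this note shows. Statements on the series, on what has been measured and on what is new or still open speak of the compounds shown alone.

Measured so far in a functional assay on Huh7.5.1 cells (Homo sapiens) for cytotoxicity, read by MTT assay, with a stated time of 72 h; on this read-out lower numbers stand for higher toxicity in this test and higher numbers for lower toxicity in this test:
Compound 1 `C=c1[nH]c(=O)/c(=C/c2ccccc2)[nH]c1=O`: > 20000 nM
Compound 2 `C=c1[nH]c(=O)/c(=C/c2ccsc2)[nH]c1=O`: > 20000 nM

Neither entry is an exact number. Compound 1 has only a limit, > 20000 nM, in this assay. Compound 2 also has only a limit, > 20000 nM. Going by the values given here, the whole picture so far is therefore (the limit of > 20000 nM in this assay, at which 2 of the 2 values shown sit), and no measured step is available as a guide.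

Compound 3 `C=c1[nH]c(=O)/c(=C/c2ccc(C(=O)OC)cc2)[nH]c1=O` keeps the core of compound 1 and differs in one place: methoxycarbonyl in place of hydrogen on an aromatic carbon. A methoxycarbonyl stands in place of hydrogen on an aromatic carbon, para to a large group.

Among the compounds with values here, with no measured step to go on, the expectation rests on the starting point. Compound 1 gives > 20000 nM, which is a limit, so the likeliest outcome in this assay is another limit. No change beyond the scatter is expected, in either direction. The expected step is a step that the limit leaves unreadable from compound 1 to compound 3. For compound 3 the estimate is 25000 nM, with an expected range from 10000 nM to 60000 nM.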

Compound 3, half-maximal cytotoxic concentration: > 20000 nM
Compound 3: no number, only a limit; the forecaster's own chance of this, stated with the estimate: 85%; the middle value lies beyond the limit too.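

Compound 1 and compound 3 each have only a limit in this assay, not an exact number, so the step from one to the other cannot be read. The compounds shown leave open whether methoxycarbonyl in place of hydrogen changes cell toxicity at all, since all of them stop at the same point: the limit of > 20000 nM in this assay, at which 3 of the 3 values shown sit.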